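This account rests on a few compounds, and the source may have more. Where it says the series, first, only, none or still open, it means among the compounds named here.

Of the compounds shown here, three sharing one core have been measured in a functional assay on HCC 2998 cells (Homo sapiens) for antiproliferative activity, with a stated time of 48 h; a higher number here means a weaker inhibitor of growth, a lower number a stronger inhibitor of growth. Compound 1 `Cc1cc(O)c(C2=NN(c3ccc(S(N)(=O)=O)cc3)C(c3ccccc3Cl)C2)cc1Cl` gives 2100 nM. Compound 2 `Cc1cc(O)c(C2=NN(c3ccc(S(N)(=O)=O)cc3)C(/C=C/c3ccccc3)C2)cc1Cl` gives 9890 nM. Compound 3 `COc1ccc(C2CC(c3cc(Cl)c(C)cc3O)=NN2c2ccc(S(N)(=O)=O)cc2)cc1OC` gives 2720 nM, the second highest of the three numbers; its nearest neighbour is compound 1 and its furthest is compound 2. The steps between them read: a 4.7-fold higher number from compound 1 to compound 2 (0.67 log units; beyond the scatter); a 1.3-fold higher number from compound 1 to compound 3 (0.11 log units; within the scatter); a 3.6-fold lower number from compound 2 to compound 3 (0.56 log units; beyond the scatter). The two steps that lie beyond the scatter both involve the 2-phenylethenyl group of compound 2, whereas the exchange of one group for another on the saturated ring carbon between compound 1 and compound 3 stays within the scatter.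

Compound 4 `COc1ccc(C2CC(c3cc(Cl)c(C)cc3O)=NN2c2ccc(S(N)(=O)=O)cc2)c(OC)c1OC` differs from compound 3 by methoxy in place of hydrogen on an aromatic carbon. For the measured compounds named here, no measured step adds or removes a single methoxy group, so there is no direct precedent. Going by the values given here, the one comparison that bears on changes to the group on the saturated ring carbon is a 1.3-fold higher number from compound 1 to compound 3 (0.11 log units; within the scatter), which is within the scatter. A step of no more than the scatter is therefore expected in this assay, with no direction claimed. Compound 4 is estimated at 3000 nM, within 1200 nM to 7500 nM. Compound 4 is thus expected to show a 1.1-fold higher number from compound 3 to compound 4 (0.04 log units; within the scatter).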

Compound 4, concentration for 50% growth inhibition: 1840 nM
The estimate for compound 4 lay 1.6-fold (0.21 log units) above the measured number, and the stated range covers the measured number.
By their numbers in this assay, from the lowest: compounds 4, 1 and 3 (each within the scatter of the next); then compound 2.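

In this assay, for the compounds shown here, methoxy in place of hydrogen, ortho to a large group and to a methoxy group, gives the first reading of a single added methoxy on this ring (a 1.5-fold lower number from compound 3 to compound 4 (0.17 log units; within the scatter)), and the change from 3,4-dimethoxyphenyl to 2,3,4-trimethoxyphenyl stays within the scatter. Going by these compounds alone, the 2,3,4-trimethoxyphenyl group on the saturated ring carbon also cannot be separated from 2-chlorophenyl (a 1.1-fold lower number from compound 1 to compound 4 (0.06 log units; within the scatter)), while its exchange for 2-phenylethenyl lies beyond the scatter (a 5.4-fold lower number from compound 2 to compound 4 (0.73 log units; beyond the scatter)), so compound 2 remains the only compound set apart, now from three substituted phenyl compounds that read alike. No measurement on these compounds accounts for these readings.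

On these data alone, whether this same ring position would also stay within the scatter with a group unlike methoxy, such as an amine, a carboxylic acid or a longer alkoxy chain, remains open. Also open, as far as these compounds go, is whether the added methoxy would read the same on a ring without the 3,4-dimethoxy pattern, as on the 2-chlorophenyl ring of compound 1, and whether the small step seen in this assay would hold in other cells.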